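This account rests on a few compounds, and the source may have more. Where it says the series, first, only, none or still open, it means among the compounds named here.

Measured compounds:
- compound 1, `O=C(NO)c1ccc(NCc2nc(-c3ccc(F)cc3)nn2-c2ccccc2)cc1`, giving 70.9%
- compound 2, `O=C(NO)c1ccc(NCc2nc(-c3ccc(Br)o3)nn2-c2ccccc2)cc1`, giving 55.8%
- compound 3, `Cc1ccsc1-c1nc(CNc2ccc(C(=O)NO)cc2)n(-c2ccccc2)n1`, giving 72.1%

In an assay on Sf9 cells for inhibition of protein deacetylase HDAC6 (Homo sapiens), read by fluorescence, with a stated time of 40 min, tested at 100 nM (on this read-out higher numbers stand for more inhibition at the one concentration tested (going by the name of the read-out) and lower numbers for less inhibition), compound 3 stands at the top of the three numbers, but the step of a number 1.2 percentage points higher from compound 1 to compound 3 (within the scatter) is within the scatter, so compound 1 and compound 3 cannot be told apart on this read-out. Only compound 2 sits clearly apart, as the step of a number 16.3 percentage points higher from compound 2 to compound 3 (beyond the scatter) shows, and likewise the step of a number 15.1 percentage points lower from compound 1 to compound 2 (beyond the scatter).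

Compound 4, `O=C(NO)c1ccc(NCc2nc(-c3cccc4cnccc34)nn2-c2ccccc2)cc1`, is not yet measured. It differs from compound 3 in one place: isoquinolin-5-yl in place of 3-methylthiophen-2-yl on an aromatic carbon. All three measured steps swap the group at this same position, and they range from a change within the scatter to a modest drop. None of them, however, involves a group of two fused rings, so the data give no direct guide to isoquinolin-5-yl; they only show that, across several aromatic groups at this position, the number stays level or falls modestly.

On that basis, a small change is expected for compound 4, the step of a number 8.1 percentage points lower from compound 3 to compound 4 (within the scatter), lying within or just beyond the scatter. Compound 4 is therefore estimated at 64% in this assay, with a range from 45% to 80%.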

Compound 4, a percentage reported as inhibition, at one concentration (the size of the read-out at that concentration, not a potency): 40.2%
Compound 4: the middle estimate sits 23.8 percentage points above what was measured; measured number outside the range, below it.
By their numbers in this assay, from the lowest: compound 4; then compound 2; then compounds 1 and 3 (each within the scatter of the next).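

Among these compounds, at this position, on an aromatic carbon between two ring nitrogen atoms, the earlier swaps left the number level or only modestly lower, but isoquinolin-5-yl, the only group here with two fused rings, gives large falls in this assay (a number 31.9 percentage points lower from compound 3 to compound 4 (beyond the scatter); a number 30.7 percentage points lower from compound 1 to compound 4 (beyond the scatter)). Even measured against the lowest of the earlier compounds, the number still falls (a number 15.6 percentage points lower from compound 2 to compound 4 (beyond the scatter)), so compound 4 sits clearly below all three and the position does not accept every aromatic group equally. Nothing available explains this fall.

The compounds shown cannot say whether the fall goes with the two fused rings as such or with where the ring nitrogen lies in them, and a naphthalen-1-yl group, with two fused rings of carbon only, would separate these two readings. Going by these compounds, how the number responds to a non-aromatic group at this position, such as a morpholine or a short alkyl chain, also stays open.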